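Chain length and an ester-to-hydrazide swap on a shared core

The source may hold more compounds than are shown below. What is called first, only, known or untested is meant among the compounds shown, and "the series" means these compounds.

Measured so far:
compound 1, `COC(=O)CN1C(=O)c2ccccc2NC1c1ccccc1`, 930 nM in an assay on mitochondria for inhibition of Amine oxidase [flavin-containing] A (Bos taurus), read by fluorescence, with a stated time of 60 min; a lower number here means a stronger inhibitor, a higher number a weaker inhibitor
compound 2, `COC(=O)CCN1C(=O)c2ccccc2NC1c1ccccc1`, 92 nM in this assay

Going by the values given here, compound 2 gives the lowest number of the two measured, with compound 1 as its only neighbour; the step of a 10-fold lower number from compound 1 to compound 2 (1.00 log units; beyond the scatter) sets the two apart beyond the scatter. Compound 3, `NNC(=O)CCCN1C(=O)c2ccccc2NC1c1ccccc1`, differs from compound 2 by (aminocarbamoyl)methyl in place of methoxycarbonyl on a saturated chain carbon, two bonds along the chain from an amide-type nitrogen in a ring. Among the compounds with values here, only one measured step bears on it: the lengthening of the chain from compound 1 to compound 2, a 10-fold lower number from compound 1 to compound 2 (1.00 log units; beyond the scatter), which is modest but clear. Within the data shown here, the further lengthening in compound 3 points the same way, yet the ester-to-hydrazide exchange has no measured counterpart in this set, so the direction is uncertain. On balance a small further gain in this assay is expected, a 1.5-fold lower number from compound 2 to compound 3 (0.19 log units; within the scatter), with wide bounds. Compound 3 is therefore estimated at 60 nM, between 12 nM and 350 nM.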

Compound 3, half-maximal inhibitory concentration: 47 nM
Estimate against measurement, compound 3: 1.3-fold (0.11 log units) above; the range from low to high includes it.
By their numbers in this assay, from the lowest: compounds 3 and 2 (each within the scatter of the next); then compound 1.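

In this assay the exchange of 2-(methoxycarbonyl)ethyl for 3-(aminocarbamoyl)propyl gives a 2.0-fold lower number from compound 2 to compound 3 (0.29 log units; within the scatter) and so leaves compound 3 and compound 2 indistinguishable, which shows that this position accepts the hydrazide on its longer chain, with its two hydrogen-bond donors, while staying at the level of the ester. The gap to the shortest chain also holds with this new end group, at a 20-fold lower number from compound 1 to compound 3 (1.30 log units; beyond the scatter) and thus large. No measurement on hand accounts for either result.

Chain length and end group change together in compound 3, so their separate shares remain open, and 3-(methoxycarbonyl)propyl or 2-(aminocarbamoyl)ethyl on the shared core would be needed to separate them. Also open, as far as these compounds go, is whether a carboxylic acid, a primary amide or a longer chain would hold this level.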